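This account rests on a few compounds, and the source may have more. Where it says the series, first, only, none or still open, it means among the compounds named here.

Measured in a functional assay on PC-3 cells (Homo sapiens) for antiproliferative activity, read by MTT assay, with a stated time of 48 h; a lower number here means a stronger inhibitor, a higher number a weaker inhibitor:
- Compound 1 `C#CCCOC(=O)c1ccc(C(CC)(CC)c2ccc(OCCC(O)(CC)CC)c(C)c2)n1CC`: > 50000 nM, a limit and not a number.
- Compound 2 `CCn1c(C(=O)NC(CO)CCO)ccc1C(CC)(CC)c1ccc(OCCC(O)(CC)CC)c(C)c1`: 8760 nM.

Among the compounds with values here, compound 2 is the only compound so far with an actual number. Compound 3 `CCn1c(C(=O)NC(C)CO)ccc1C(CC)(CC)c1ccc(OCCC(O)(CC)CC)c(C)c1` differs from it by hydrogen in place of hydroxymethyl on a saturated chain carbon, two bonds along the chain from an amide-type nitrogen: hydrogen in place of hydroxymethyl, which also reads as 2-hydroxyethyl to methyl. Within the data shown here, the only measured step that bears on this is an at least 5.7-fold lower number from compound 1 to compound 2 (0.75 log units; beyond the scatter), which replaced the whole group on the carbonyl carbon. The present change is smaller, so no shift beyond the scatter is expected in this assay, and the estimated step is a 1.1-fold higher number from compound 2 to compound 3 (0.06 log units; within the scatter). For compound 3 the expected value is 10000 nM, with an estimated range of 3500 nM to 35000 nM.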

Compound 3, half-maximal inhibitory concentration: 7870 nM
For compound 3 the middle estimate is 1.3-fold (0.10 log units) above the measured one; measured number inside the range.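

In this assay, taking the hydroxymethyl off this saturated chain carbon, two bonds along the chain from an amide-type nitrogen, gives a 1.1-fold lower number from compound 2 to compound 3 (0.05 log units; within the scatter), so compound 3 matches compound 2 and this hydroxymethyl is not required for the activity seen. The smaller 1-(hydroxymethyl)ethyl amide also stands clear of the (but-3-yn-1-yl)oxy group: an at least 6.3-fold lower number from compound 1 to compound 3 (0.80 log units; beyond the scatter). The value of compound 1 is a limit and not a number: the limit of > 50000 nM in this assay, at which 1 of the 3 values shown sits.

The compounds shown leave open whether the remaining hydroxymethyl of compound 3 matters. They also leave open how an amine, a carboxylic acid or a longer chain would read on this carbon.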